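Dropping One Methyl From Compound 3

The compounds below may be only part of what the source reports. "The series", "measured", "known", "first", "only" and "open" are said of these compounds alone.

Measured so far in a physicochemical assay for lipophilicity, using the shake flask method, in phosphate buffer, measured as octanol-water partition, with a stated time of 24 h, at pH 7.4, tested at 100 uM (on this read-out higher numbers stand for higher lipophilicity and lower numbers for lower lipophilicity), are these compounds
- compound 1 `Cc1cc(OCC(C)C)cc(C)c1-c1cccc(COc2ccc(OCC(=O)O)c(F)c2)c1` gives "not determined" (no result reported)
- compound 2 `Cc1cc(OCCOCc2ccccc2)cc(C)c1-c1cccc(COc2ccc(OCC(=O)O)c(F)c2)c1` gives "not determined" (no result reported)
- compound 3 `Cc1cc(OCCCS(C)(=O)=O)cc(C)c1-c1cccc(COc2ccc(OCC(=O)O)c(F)c2)c1` gives 1.81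

Compound 3 alone carries a number here, so its place cannot be ranked, and neither compound 1 nor compound 2 offers a comparison. Compound 4 `Cc1cc(OCCCS(C)(=O)=O)ccc1-c1cccc(COc2ccc(OCC(=O)O)c(F)c2)c1` has not yet been measured. It differs from compound 3 at a single place (hydrogen in place of methyl on an aromatic carbon): hydrogen in place of methyl on an aromatic carbon. For the measured compounds named here, no measured pair in this set shows what such a change does, so the expectation rests on the structural change alone. Starting from compound 3 at 1.81 a modest step downward is expected, and it may barely clear the usual scatter. The estimated change is a number 0.36 log units lower from compound 3 to compound 4 (beyond the scatter) and nothing larger is expected. For compound 4 the estimated value is 1.45 with an expected range from 1.1 to 1.8 on this read-out.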

Compound 4, distribution coefficient: 1.63
Estimate against measurement, compound 4: 0.18 log units below, within the range that was stated.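

Hydrogen in place of methyl on this aromatic carbon, ortho to a large group, gives a number 0.18 log units lower from compound 3 to compound 4 (within the scatter) in this assay and provides the first measured pair in this set. For the compounds shown here, on this read-out, compound 3 and compound 4 cannot be told apart, so this single methyl, with the second methyl and the 3-(methylsulfonyl)propoxy group left in place, shows no step that stands clear of repeated measurement. Nothing in hand gives a reason for the size of this step.

On these data alone, it remains open whether taking away the second methyl as well, or placing a chlorine atom or a methoxy group on this carbon, would give a step beyond the scatter. Also open, as far as these compounds go, is what an amine or a longer chain would do in place of the 3-(methylsulfonyl)propoxy group in this assay on this read-out.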